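Crotonamide tail variation on the dihydroindole-bearing quinazoline core

The compounds below may be only part of what the source reports. "The series", "measured", "known", "first", "only" and "open" are said of these compounds alone.

Measured in a functional assay on MCF7 cells (Homo sapiens) for antiproliferative activity, read by MTT assay, with a stated time of 72 h; on this read-out higher numbers stand for weaker inhibition and lower numbers for stronger inhibition:
- compound 1 `C=C(C)C(=O)Nc1cc2c(N3CCc4ccccc43)ncnc2cc1OC`: 11100 nM
- compound 2 `C/C=C/C(=O)Nc1cc2c(N3CCc4ccccc43)ncnc2cc1OC`: 4030 nM
- compound 3 `COc1cc2ncnc(N3CCc4ccccc43)c2cc1NC(=O)/C=C/CN(C)C`: 3370 nM

Compound 3 carries the lowest number of the three, but its separation from compound 2 is within the scatter, so the two cannot be ranked; only compound 1 stands apart, as seen in a 3.3-fold lower number from compound 1 to compound 3 (0.52 log units; beyond the scatter) and a 2.8-fold lower number from compound 1 to compound 2 (0.44 log units; beyond the scatter).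

Compound 4 `COc1cc2ncnc(N3CCc4ccccc43)c2cc1NC(=O)/C=C/CN1CCCCC1` differs from compound 3 in one place: piperidin-1-yl in place of dimethylamino on a saturated chain carbon bound to a double-bonded chain carbon. Among the measured compounds shown here, the only measured step that touches this end of the chain is a 1.2-fold lower number from compound 2 to compound 3 (0.08 log units; within the scatter), which was within the scatter; nothing measured speaks to the size of the amine itself. On this basis no step beyond the scatter is expected in this assay for compound 4, in either direction.

Compound 4 is therefore estimated at 3000 nM in this assay, with a range of 1200 nM to 8000 nM. The expected step is a 1.1-fold lower number from compound 3 to compound 4 (0.05 log units; within the scatter).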

Compound 4, half-maximal inhibitory concentration: 1680 nM
The estimate for compound 4 lay 1.8-fold (0.25 log units) above the measured number; measured number inside the range.
By their numbers in this assay, from the lowest: compounds 4, 3 and 2 (each within the scatter of the next, the first and the last beyond it); then compound 1.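

In this assay, the change from dimethylamino to piperidin-1-yl on a saturated chain carbon bound to a double-bonded chain carbon gives a 2.0-fold lower number from compound 3 to compound 4 (0.30 log units; within the scatter) and so leaves the two unranked. Against hydrogen at the same carbon, however, piperidin-1-yl gives a 2.4-fold lower number from compound 2 to compound 4 (0.38 log units; beyond the scatter) and thus a separation beyond the scatter that dimethylamino did not reach, while a 6.6-fold lower number from compound 1 to compound 4 (0.82 log units; beyond the scatter) is the widest step in the set. No measurement shown accounts for these differences.

As far as these compounds go, whether the separation from hydrogen depends on the six-membered ring or on the larger amine in general stays open, and pyrrolidin-1-yl, morpholin-4-yl or 4-methylpiperazin-1-yl on the same carbon would bear on that. A longer chain between the double bond and the amine also remains an open question.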